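Nitroso for nitro on the pyridyl arm of compound 1

The source may hold more compounds than are shown below. What is called first, only, known or untested is meant among the compounds shown, and "the series" means these compounds.

Compound 1 `CCCN(CCC)c1cc(C)nc2c(-c3ncc(C)cc3[N+](=O)[O-])c(C)nn12` is measured in an assay on isolated protein for binding affinity to corticotropin-releasing factor receptor 1 (Homo sapiens) (a lower number here means a stronger inhibitor, a higher number a weaker inhibitor), at 14 nM. Among the three measured members it stands second highest. Compound 3 `CCCN(CCC)c1cc(C)nc2c(-c3ncc(F)cc3C)c(C)nn12` gives 19 nM, which lies within the scatter of compound 1. Compound 2 `CCCN(CCC)c1cc(C)nc2c(-c3ncc(Cl)cc3C)c(C)nn12` gives 6.7 nM, a lower number than compound 1 that lies beyond the scatter. Among the measured compounds shown here, the one measured step that changes a single place, fluoro in place of chloro on an aromatic carbon, is a 2.8-fold higher number from compound 2 to compound 3 (0.45 log units; beyond the scatter), a modest effect.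

Compound 4 `CCCN(CCC)c1cc(C)nc2c(-c3ncc(C)cc3N=O)c(C)nn12` differs from compound 1 as follows: a group of 2 heavy atoms (1 nitrogen, 1 oxygen; no ring) in place of a group of 3 heavy atoms (1 nitrogen, 2 oxygen; no ring), on an aromatic carbon. The group sits on an aromatic carbon of a six-membered aromatic ring with 1 nitrogen, two atoms from the ring nitrogen. For the measured compounds named here, no measured step touches this group; the step from compound 2 to compound 3 concerns a different position and a different pair of groups, so it gives only a sense of scale for a small change on this ring. The expected step in this assay is therefore a 1.4-fold higher number from compound 1 to compound 4 (0.15 log units; within the scatter), small and not clearly resolved from the scatter, with a wide range. Compound 4 is estimated at 20 nM, between 7 nM and 60 nM.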

Compound 4, inhibition constant: > 10000 nM
Compound 4: no number, only a limit (the forecaster's own chance of this, stated with the estimate: 3%); middle value at least 500-fold (2.69 log units) away from the limit.
By their numbers in this assay, from the lowest: compound 2; then compounds 1 and 3 (each within the scatter of the next). At a limit, above all of these: compound 4.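

Among the compounds shown here, at this place, on an aromatic carbon of a six-membered aromatic ring with 1 nitrogen and ortho to a large group, nitroso in place of nitro gives an at least 710-fold higher number from compound 1 to compound 4 (2.85 log units; beyond the scatter) in this assay even though the computed counts of hydrogen-bond donors and acceptors stay the same, so this position tolerates far less change than the earlier compounds could show. The reading for compound 4 is a limit and not a number, so the step has a floor but no known size: the limit of > 10000 nM in this assay, at which 1 of the 4 values shown sits. For the compounds shown here, the steps of an at least 520-fold higher number from compound 3 to compound 4 (2.72 log units; beyond the scatter) and an at least 1400-fold higher number from compound 2 to compound 4 (3.17 log units; beyond the scatter) change the whole pyridyl arm and not one group, yet they too set compound 4 far from the other members, where the only earlier step, a 2.8-fold higher number from compound 2 to compound 3 (0.45 log units; beyond the scatter), was modest.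

As far as these compounds go, whether an amine or a nitrile on this same aromatic carbon would stay close to compound 1 or move as far as compound 4 remains open. The compounds shown also give no actual number for compound 4 and no reason for so large a step from so small a change.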